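The source may report more compounds than this note shows. Statements on the series, on what has been measured and on what is new or still open speak of the compounds shown alone.

Measured so far:

Compound 1 `C=CC(=O)Nc1cccc(NC(=O)CSc2nc(Nc3cccc(Cl)c3)c3ccccc3n2)c1`: 9460 nM
Compound 2 `C=CC(=O)Nc1cccc(NC(=O)CSc2nc(Nc3cccc(Br)c3)c3ccccc3n2)c1`: 12100 nM
Compound 3 `C=CC(=O)Nc1cccc(NC(=O)CSc2nc(Nc3ccc(Cl)cc3)c3ccccc3n2)c1`: 7580 nM

All three were tested in a functional assay on NCI-H1975 cells (Homo sapiens) for inhibition, read by MTT assay, with a stated time of 72 h; on this read-out higher numbers stand for weaker inhibition and lower numbers for stronger inhibition. Compound 1 and compound 2 share a core and differ only in one group: bromo in place of chloro on an aromatic carbon. That exchange gave a 1.3-fold higher number from compound 1 to compound 2 (0.11 log units; within the scatter), so the two numbers cannot be told apart with confidence. Compound 3 carries a different core, and its relation to compound 1 is 4-chlorophenyl in place of 3-chlorophenyl on a nitrogen on an aromatic ring; the two values again sit close, as a 1.2-fold lower number from compound 1 to compound 3 (0.10 log units; within the scatter) shows. The pair of compound 2 and compound 3 is no further apart than that, with a 1.6-fold lower number from compound 2 to compound 3 (0.20 log units; within the scatter).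

Compound 4 `C=CC(=O)Nc1cccc(NC(=O)CSc2nc(Nc3ccc(Br)cc3)c3ccccc3n2)c1` has not yet been tested. It relates to compound 3 in the same way as compound 2 relates to compound 1: bromo in place of chloro on an aromatic carbon. The surroundings are not identical, since the group in compound 2 sits meta to a large group whereas in compound 4 it sits para to a large group, so this is the same kind of change rather than the same change.

The expectation for compound 4 rests on compound 1 and compound 2, where the exchange of chloro for bromo produced a 1.3-fold higher number from compound 1 to compound 2 (0.11 log units; within the scatter). The corresponding step from compound 3 is therefore expected to be small, about a 1.2-fold higher number from compound 3 to compound 4 (0.08 log units; within the scatter). On that basis compound 4 is estimated at 9200 nM, with a likely range from 5000 nM to 17000 nM.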

Compound 4, half-maximal inhibitory concentration: 6280 nM
The estimate for compound 4 lay 1.5-fold (0.17 log units) above the measured number; the range from low to high includes it.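

In this assay, the exchange of chloro for bromo, para to a large group, gives a 1.2-fold lower number from compound 3 to compound 4 (0.08 log units; within the scatter), and the two steps that take a 3-halophenyl group to 4-bromophenyl are also inside the usual scatter, at a 1.9-fold lower number from compound 2 to compound 4 (0.28 log units; within the scatter) and a 1.5-fold lower number from compound 1 to compound 4 (0.18 log units; within the scatter). Set beside the earlier exchange, the new step cannot be told apart from it, so the change carries over as a small step: the same change on two cores in this assay, a 1.3-fold higher number (0.11 log units; within the scatter) from compound 1 to compound 2 and a 1.2-fold lower number (0.08 log units; within the scatter) from compound 3 to compound 4, 1.5-fold (0.19 log units) apart, within the scatter of two such steps. This shows that in these two pairs the exchange left numbers that cannot be separated with confidence, but it does not show a direction, since one step reads higher and the other lower, and two pairs in one cell assay cannot show that the exchange would stay this small on other cores or in other tests.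

The compounds shown leave open what a fluoro, a methoxy or an amine on the same phenyl ring would do, since only chloro and bromo appear there. They also leave open how the numbers would move if the acrylamide were replaced by a plain acetamide, or if the sulfur-containing linker were exchanged for a longer chain.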